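Dichlorophenyl swap from compound 3 to compound 4

The compounds below may be only part of what the source reports. "The series", "measured", "known", "first", "only" and "open" are said of these compounds alone.

In a functional assay on HT-1080 cells (Homo sapiens) for cytotoxicity, read by MTT assay, with a stated time of 72 h (on this read-out lower numbers stand for stronger inhibition and higher numbers for weaker inhibition), compound 1 `COc1ccc(/C=C2\CCC/C(=C\c3ccccc3Cl)C2=O)cc1OC` gives 6800 nM, compound 2 `COc1ccc(/C=C2\CCC/C(=C\c3ccccc3Br)C2=O)cc1OC` gives 8400 nM and compound 3 `COc1ccc(/C=C2\CCC/C(=C\c3cccc(Cl)c3Cl)C2=O)cc1OC` gives 8800 nM. Going by the values given here, compound 3 therefore stands level with the other two, as no pair among the three is separated beyond the scatter.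

Compound 4 `COc1ccc(/C=C2\CCC/C(=C\c3ccc(Cl)cc3Cl)C2=O)cc1OC` has the same atoms as compound 3, joined differently: 2,4-dichlorophenyl in place of 2,3-dichlorophenyl on a double-bonded chain carbon bound to a double-bonded ring carbon. The change places 2,4-dichlorophenyl where 2,3-dichlorophenyl stood, on a double-bonded chain carbon bound to a double-bonded ring carbon.

Among the compounds with values here, three measured steps bear on this change. Chloro in place of hydrogen on an aromatic carbon gave a 1.3-fold higher number from compound 1 to compound 3 (0.11 log units; within the scatter). Bromo in place of chloro gave a 1.2-fold higher number from compound 1 to compound 2 (0.09 log units; within the scatter), and 2,3-dichlorophenyl in place of 2-bromophenyl gave a 1.0-fold higher number from compound 2 to compound 3 (0.02 log units; within the scatter). All three changes fall on the same aromatic ring, and none moves the number beyond the scatter. None of them tests the 2,4-dichlorophenyl group itself, so the range is kept wide.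

The estimated change is a 1.1-fold lower number from compound 3 to compound 4 (0.05 log units; within the scatter), and no step beyond the scatter is expected. The expected value for compound 4 is 7800 nM, with an estimated range from 4200 nM to 14000 nM.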

Compound 4, half-maximal inhibitory concentration: 10500 nM
The estimate for compound 4 lay 1.3-fold (0.13 log units) below the measured number; measured number inside the range.
By their numbers in this assay, from the lowest: compounds 1, 2, 3 and 4 (each within the scatter of the next).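

In this assay, going by these compounds alone, 2,4-dichlorophenyl in place of 2,3-dichlorophenyl on a double-bonded chain carbon bound to a double-bonded ring carbon gives a 1.2-fold higher number from compound 3 to compound 4 (0.08 log units; within the scatter) and is the first step that changes only how the two chlorines are arranged on this ring; that rearrangement does not separate the two compounds. The new group also stays level with the singly halogenated rings: the replacement of 2-bromophenyl gives a 1.3-fold higher number from compound 2 to compound 4 (0.10 log units; within the scatter) and chloro in place of hydrogen on an aromatic carbon gives a 1.5-fold higher number from compound 1 to compound 4 (0.19 log units; within the scatter) so all four compounds remain within the scatter of the next, and neither a second chlorine nor its arrangement has yet moved the number. No measurement at hand accounts for where these numbers fall.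

Within the data shown here, every group at this place so far is a halogenated phenyl, so it remains open whether an amine or a carboxylic acid on this ring would move the number beyond the scatter. Also open, as far as these compounds go, is what a change would do on the dimethoxyphenyl side of the shared core, which is the same in all four compounds.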